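The compounds below may be only part of what the source reports. "The series", "measured", "known", "first", "only" and "open" are said of these compounds alone.

Of the compounds shown here, two of a shared core have been tested so far. Compound 1 `O=C(Nc1nc2ccc(NC(=O)C3CCCO3)cc2s1)C1CCCCC1` carries a cyclohexyl ring on one side and a five-membered oxygen ring on the other; in a functional assay on WI-38 VA13 cells (Homo sapiens) for cytotoxicity (a lower number here means that less compound is needed, a higher number that more compound is needed for the effect), compound 1 gives 1.3 ug/mL. Compound 2 `NCCC(=O)Nc1nc2ccc(NC(=O)c3c(Cl)cccc3Cl)cc2s1` carries a dichlorophenyl group on one side and an aminoethyl chain on the other; in this assay compound 2 gives 5.3 ug/mL. Of the two numbers, compound 2 has the higher one, and the gap to compound 1 lies beyond the usual scatter of repeated measurements, so more of compound 2 is needed for the same effect.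

The next compound, compound 3 `O=C(Nc1ccc2nc(NCC3CCCCC3)sc2c1)c1c(Cl)cccc1Cl`, follows from compound 2 by one change: cyclohexylmethyl in place of (2-aminoethyl)carbonyl on a nitrogen on an aromatic ring. For the measured compounds named here, no pair of measured compounds shows this particular change, so its effect has to be guessed. Going by the values given here, the only guide is that compound 1, which also carries a cyclohexyl ring, gives 1.3 ug/mL. On that basis the step of a 2.7-fold lower number from compound 2 to compound 3 (0.42 log units; beyond the scatter) is expected to move the number down, by a moderate amount. For compound 3 the expected value is 2 ug/mL, with a range from 0.7 ug/mL to 6 ug/mL.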

Compound 3, half-maximal effective concentration: 4.3 ug/mL
For compound 3 the middle estimate is 2.2-fold (0.33 log units) below the measured one; the measured number falls inside the stated range.
By their numbers in this assay, from the lowest: compound 1; then compounds 3 and 2 (each within the scatter of the next).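

Replacing (2-aminoethyl)carbonyl with cyclohexylmethyl on a nitrogen on an aromatic ring is a large exchange on paper: the group that leaves holds a carbonyl and a nitrogen along with hydrogen-bond donors and acceptors, whereas the group that enters is carbon only and brings a six-membered ring. Even so, this assay shows a 1.2-fold lower number from compound 2 to compound 3 (0.09 log units; within the scatter), so this position accepts two very different groups, and the two compounds cannot be told apart by their numbers. No measurement at hand accounts for this close agreement.

Because the ring, the carbonyl and the chain nitrogen all change in one step, the compounds shown do not separate what each of these parts contributes, and groups such as a simple amine, a carboxylic acid or a longer carbon chain on this nitrogen would test how far the agreement extends. Going by these compounds, it also remains open whether the same exchange would give a similar result with a group other than the dichlorophenyl group elsewhere on the shared core.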